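The source may hold more compounds than are shown below. What is called first, only, known or untested is meant among the compounds shown, and "the series" means these compounds.

Going by the values given here, compound 2 `C=C1[C@@H](OC(C)=O)C[C@@H]2[C@](C)(COC=O)[C@H](OC(C)=O)CC[C@@]2(C)[C@@H]1C[C@@H](Nc1ccccc1F)C1=CCOC1=O` is the first point of reference: in a functional assay on HT-29 cells (Homo sapiens) for cytotoxicity, read by sulforhodamine B assay (on this read-out higher numbers stand for weaker inhibition and lower numbers for stronger inhibition), compound 2 gives 9760 nM. Compound 1 `C=C1[C@@H](OC(C)=O)C[C@@H]2[C@](C)(COC=O)[C@H](OC(C)=O)CC[C@@]2(C)[C@@H]1C[C@@H](Nc1cccc(F)c1)C1=CCOC1=O` differs from it only by 3-fluorophenyl in place of 2-fluorophenyl on an amine nitrogen, and in this assay compound 1 gives 9410 nM, so the step of a 1.0-fold lower number from compound 2 to compound 1 (0.02 log units; within the scatter) is one the assay cannot tell from no change. Compound 3 `C=C1[C@@H](OC(C)=O)C[C@@H]2[C@](C)(CO[Si](C)(C)C(C)(C)C)[C@H](OC(C)=O)CC[C@@]2(C)[C@@H]1C[C@@H](Nc1ccccc1F)C1=CCOC1=O` keeps the 2-fluorophenyl of compound 2 and alters the core by a group of 7 heavy atoms (6 carbon, 1 silicon; no ring) in place of a group of 2 heavy atoms (1 carbon, 1 oxygen; no ring), on an oxygen on a saturated carbon; in this assay compound 3 gives 3710 nM, which makes a 2.6-fold lower number from compound 2 to compound 3 (0.42 log units; beyond the scatter) a modest but real step and leaves compound 3 with the lowest number of the three.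

Compound 4 `C=C1[C@@H](OC(C)=O)C[C@@H]2[C@](C)(CO[Si](C)(C)C(C)(C)C)[C@H](OC(C)=O)CC[C@@]2(C)[C@@H]1C[C@@H](Nc1cccc(F)c1)C1=CCOC1=O` has not yet been measured. It stands to compound 3 as compound 1 stands to compound 2: the change is 3-fluorophenyl in place of 2-fluorophenyl on an amine nitrogen, at the same place, so it is the same change made on the core of compound 3 rather than on the core of compound 2. Because the earlier step of a 1.0-fold lower number from compound 2 to compound 1 (0.02 log units; within the scatter) stayed within the scatter, the step of a 1.0-fold higher number from compound 3 to compound 4 (0.01 log units; within the scatter) is expected to be small as well. For compound 4 in this assay the estimate is 3800 nM, with a likely range from 1800 nM to 8000 nM.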

Compound 4, half-maximal inhibitory concentration: 4520 nM
Compound 4: middle estimate off by 1.2-fold (0.08 log units), on the low side, within the range that was stated.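

Putting 3-fluorophenyl in place of 2-fluorophenyl on the amine nitrogen gives a 1.2-fold higher number from compound 3 to compound 4 (0.09 log units; within the scatter) in this assay, so this exchange carries from one core to the other with no difference the assay can resolve: the same change on two cores in this assay, a 1.0-fold lower number (0.02 log units; within the scatter) from compound 2 to compound 1 and a 1.2-fold higher number (0.09 log units; within the scatter) from compound 3 to compound 4, 1.3-fold (0.10 log units) apart, within the scatter of two such steps. The group of 6 carbon and 1 silicon in place of the smaller group on the oxygen gives a 2.1-fold lower number from compound 1 to compound 4 (0.32 log units; beyond the scatter), and that step also keeps its size whichever fluorophenyl is present: the same change on two cores in this assay, a 2.6-fold lower number (0.42 log units; beyond the scatter) from compound 2 to compound 3 and a 2.1-fold lower number (0.32 log units; beyond the scatter) from compound 1 to compound 4, 1.3-fold (0.10 log units) apart, within the scatter of two such steps. Going by these compounds alone, these two pairs show only that the two changes act independently within these four compounds; they do not show that this holds for other groups, nor do they explain either step.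

The compounds shown leave open whether a chlorine or a methoxy group on the phenyl ring, or a plain phenyl, would also leave the number unchanged on both cores. They also leave open whether a free hydroxyl on that oxygen would follow the same pattern.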